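The source may report more compounds than this note shows. Statements on the series, on what has been measured and on what is new or still open speak of the compounds shown alone.

Of the compounds shown here, three that share one core have been measured in an ADME assay on microsomes from liver (Homo sapiens) for metabolic stability, read by LC-MS, using NADPH; a higher number here means faster removal of the compound, a lower number slower removal. Compound 1 `CCC(C)(C)C(=O)N(O)Cc1cc(F)cc(F)c1F` gives 10.4 uL/min in this assay. Compound 2 `CCC(C)(C)C(=O)N(O)Cc1ccc(F)c(F)c1F` gives 13.1 uL/min in this assay. Compound 3 `CCC(C)(C)C(=O)N(O)Cc1ccc(F)cc1F` gives 3.5 uL/min in this assay, the lowest of the three numbers, with compound 1 giving a higher number than compound 3. For the measured compounds named here, the only single-change step measured so far runs a 3.7-fold lower number from compound 2 to compound 3 (0.57 log units; beyond the scatter). Compound 4 `CCC(C)(C)C(=O)N(O)Cc1ccc(F)cc1` has not yet been measured. It differs from compound 3 by hydrogen in place of fluoro on an aromatic carbon. This is the same kind of change as the measured step from compound 2 to compound 3, so that step bears directly on it, and the higher number of compound 1 against compound 3 points the same way. On that basis a modest drop in this assay is expected for compound 4, though a single precedent leaves the outcome uncertain, and no change beyond the scatter remains possible. For compound 4 the estimate in this assay is 2.5 uL/min, ranging from 1 uL/min to 7 uL/min, meaning an expected step of a 1.4-fold lower number from compound 3 to compound 4 (0.15 log units; within the scatter).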

Compound 4, intrinsic clearance in a liver preparation (reported as CLH), per the amount of preparation that the assay uses: 3.9 uL/min
The estimate for compound 4 lay 1.6-fold (0.19 log units) below the measured number, and the stated range covers the measured number.
By their numbers in this assay, from the lowest: compounds 3 and 4 (each within the scatter of the next); then compounds 1 and 2 (each within the scatter of the next).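

In this assay, removing the fluoro group that sits ortho to a large group and meta to a fluoro group gives a 1.1-fold higher number from compound 3 to compound 4 (0.05 log units; within the scatter) and so leaves the clearance reading essentially unchanged. The same swap of fluoro for hydrogen at a different place on the ring gave a 3.7-fold lower number from compound 2 to compound 3 (0.57 log units; beyond the scatter) and lies beyond the scatter, so across these two steps the size of the effect depends on where the fluoro group is removed. Nothing available here explains why the two places differ.

The compounds shown leave open whether a different group at this position, such as chloro, methyl or methoxy, would also leave the number unchanged. They also leave open what happens when the remaining fluoro group gives way to hydrogen, leaving no fluoro group on the ring.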